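This account rests on a few compounds, and the source may have more. Where it says the series, first, only, none or still open, it means among the compounds named here.

The measured compounds and their values:

Compound 1, `O=C(CCc1nc2ccccc2c(=O)[nH]1)N/N=C/c1ccc([N+](=O)[O-])cc1`: 328000000 nM
Compound 2, `O=C(CCc1nc2ccccc2c(=O)[nH]1)N/N=C/c1ccc(Cl)cc1`: 381000000 nM
Compound 3, `O=C(CCCc1nc2ccccc2c(=O)[nH]1)N/N=C/c1ccc([N+](=O)[O-])cc1`: 316000000 nM

All three were tested in a physicochemical assay, read by spectrophotometry, with a stated time of 30 min; a lower number here means a stronger inhibitor, a higher number a weaker inhibitor. Compound 1 and compound 2 share the same core and differ in one place: chloro in place of nitro on an aromatic carbon. That change gave a 1.2-fold higher number from compound 1 to compound 2 (0.07 log units; within the scatter), so the two compounds cannot be told apart by this assay. Compound 3 carries a core that differs from the core of compound 1, and the difference between the two cores is not broken down here. In this assay compound 3 gives a value that lies within the scatter of both compound 1 and compound 2, so the three numbers read as one level.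

Compound 4, `O=C(CCCc1nc2ccccc2c(=O)[nH]1)N/N=C/c1ccc(Cl)cc1`, has not yet been measured in this assay. It stands to compound 3 as compound 2 stands to compound 1: chloro in place of nitro on an aromatic carbon. The place of the change is the same in both pairs, so this is the same change made on the other core. Because the earlier step, a 1.2-fold higher number from compound 1 to compound 2 (0.07 log units; within the scatter), stayed within the scatter, the step from compound 3 to compound 4 is expected to be of similar size, a 1.2-fold higher number from compound 3 to compound 4 (0.07 log units; within the scatter). On that basis compound 4 is estimated to give 370000000 nM in this assay, with a range from 250000000 nM to 560000000 nM expected to hold most repeats.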

Compound 4, half-maximal inhibitory concentration: 353000000 nM
Compound 4: the middle estimate sits 1.0-fold (0.02 log units) above what was measured; the measured number falls inside the stated range.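

In this assay, chloro in place of nitro gave a 1.1-fold higher number from compound 3 to compound 4 (0.05 log units; within the scatter), and the same change on the other core gave a 1.2-fold higher number from compound 1 to compound 2 (0.07 log units; within the scatter), so on both cores the change leaves the number within the usual scatter. This shows that the change carries over in a limited sense: on neither core does it produce a difference that this assay can read, and the result on one core would have been a fair guide to the result on the other. It does not show that the two cores respond alike in general, since two pairs that both stay within the scatter cannot reveal whether a change that really moved the number would transfer, and no measurement shown here accounts for how little this change does.

The compounds shown leave open whether a different group on the same aromatic carbon, such as an amine or a carboxylic acid, would move the number beyond the scatter, and whether it would do so by a similar amount on both cores. Among the compounds shown here, they also leave open whether a longer chain than the one in compound 3 would separate the compounds in this assay.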